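A few compounds are considered here, and "the series" means these few. Any claim that something is new, unique, unknown or untested is made for them only; others in the source may bear on it.

Three compounds share one core and differ only in the group carried on a nitrogen on an aromatic ring. Compound 1 `Nc1cccc(Nc2c(C(=O)NCc3ccc(F)cc3)nc(Br)c3cccnc23)c1` carries 3-aminophenyl there, and in a functional assay on MDA-MB-435 cells (Homo sapiens) for cytotoxicity, read by MTT assay, with a stated time of 72 h (on this read-out lower numbers stand for stronger inhibition and higher numbers for weaker inhibition), compound 1 gives 8000 nM. Compound 2 `CN(C)CCCNc1c(C(=O)NCc2ccc(F)cc2)nc(Br)c2cccnc12` carries 3-(dimethylamino)propyl, and in this assay compound 2 gives 7000 nM. Compound 3 `N[C@H]1CC[C@H](Nc2c(C(=O)NCc3ccc(F)cc3)nc(Br)c3cccnc23)CC1` carries 4-aminocyclohexyl, and in this assay compound 3 gives 6000 nM. The three numbers sit close together: a 1.1-fold lower number from compound 1 to compound 2 (0.06 log units; within the scatter), a 1.3-fold lower number from compound 1 to compound 3 (0.12 log units; within the scatter) and a 1.2-fold lower number from compound 2 to compound 3 (0.07 log units; within the scatter). Compound 3 has the lowest of the three numbers, but both other compounds stand within the scatter of it, so nothing can be read into that.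

Compound 4 `N[C@H]1CC[C@H](Nc2c(C(=O)NC3CCCCC3)nc(Br)c3cccnc23)CC1` keeps the 4-aminocyclohexyl group of compound 3 and changes a different part of the molecule: cyclohexyl in place of 4-fluorobenzyl on an amide-type nitrogen. None of the three measured steps touches the amide-type nitrogen; each of them swaps the group on the nitrogen on an aromatic ring, and each stayed within the scatter. There is therefore no measured guide to the size or direction of this change, and the most defensible reading is that in this assay compound 4 is expected to stay near compound 3, with a wide band of uncertainty. The expected step is no change at the digits printed from compound 3 to compound 4 (within the scatter). The estimate for compound 4 in this assay is 6000 nM, in a range from 1500 nM to 25000 nM.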

Compound 4, half-maximal inhibitory concentration: > 10000 nM
Compound 4 was reported as a limit (the forecaster's own chance of this, stated with the estimate: 15%); middle value at least 1.6-fold (0.22 log units) away from the limit.
By their numbers in this assay, from the lowest: compounds 3, 2 and 1 (each within the scatter of the next). At a limit, above all of these: compound 4.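

For the compounds shown here, the earlier steps all swapped the group on the nitrogen on an aromatic ring, so this is the first reading at the amide-type nitrogen, where cyclohexyl, a non-aromatic ring of carbon only, replaces 4-fluorobenzyl, which carries an aromatic one. The step reads an at least 1.6-fold higher number from compound 3 to compound 4 (0.22 log units; that floor lies within the scatter) and so gives only a floor, not a measured size; the true gap could be small or much larger, and the data do not establish a real loss from this change. In this assay compound 4 is known only as a limit, and that limit is all there is to read: the limit of > 10000 nM in this assay, at which 1 of the 4 values shown sits.

The compounds shown leave open whether the aromatic ring or the fluorine of 4-fluorobenzyl counts at this nitrogen, a question that a plain benzyl or a 4-chlorobenzyl group there would help to separate. They also leave open how cyclohexyl on the amide-type nitrogen would read alongside 3-aminophenyl or 3-(dimethylamino)propyl, as compound 4 pairs it only with 4-aminocyclohexyl.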